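This account rests on a few compounds, and the source may have more. Where it says the series, first, only, none or still open, it means among the compounds named here.

In a functional assay on HCT-116 cells (Homo sapiens), read by MTT assay, with a stated time of 72 h (on this read-out higher numbers stand for weaker inhibition and lower numbers for stronger inhibition), compound 1 `CNc1ncnc2c1c(-c1cccs1)cn2[C@@H]1O[C@H](CO)[C@@H](O)[C@H]1O`, which carries thiophen-2-yl on its own core, gives > 20000 nM, and this is a limit of the assay rather than a number. Compound 2 `Nc1nc2c(c(-c3ccco3)cn2[C@@H]2O[C@H](CO)[C@@H](O)[C@H]2O)c(=O)[nH]1` gives > 20000 nM, again a limit. Among the compounds with values here, on the same core as compound 2, compound 3 `Nc1nc2c(c(-c3ccoc3)cn2[C@@H]2O[C@H](CO)[C@@H](O)[C@H]2O)c(=O)[nH]1` gives 14200 nM, the only actual number among the three. Compound 4 `Nc1nc2c(c(-c3cccs3)cn2[C@@H]2O[C@H](CO)[C@@H](O)[C@H]2O)c(=O)[nH]1` keeps that core and differs from compound 3 as follows: thiophen-2-yl in place of furan-3-yl on an aromatic carbon. In words, it has thiophen-2-yl in place of furan-3-yl on an aromatic carbon. Within the data shown here, the one measured step on this core is an at least 1.4-fold lower number from compound 2 to compound 3 (0.14 log units; that floor lies within the scatter), and it concerns only the furan group, so it offers no sign of a large effect from changing this substituent. Compound 4 may also be reported only as a limit, given (the limit of > 20000 nM in this assay, at which 2 of the 3 values shown sit). No shift beyond the scatter is therefore expected in this assay, and the estimate is a 1.0-fold lower number from compound 3 to compound 4 (0.01 log units; within the scatter). For compound 4 the expected value is 14000 nM, within an estimated range of 4000 nM to 30000 nM.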

Compound 4, half-maximal inhibitory concentration: > 20000 nM
Compound 4: no number, only a limit; the forecaster's own chance of this, stated with the estimate: 45%; middle value at least 1.4-fold (0.15 log units) away from the limit.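

At the aromatic carbon two ring bonds from the ring nitrogen, thiophen-2-yl in place of furan-3-yl gives in this assay an at least 1.4-fold higher number from compound 3 to compound 4 (0.14 log units; that floor lies within the scatter). Within the data shown here, the value of compound 4 is a limit and not a number, so the true size of this step stays unknown, and compound 3 remains the only compound on the shared core with an actual number. The step between the two compounds with a five-membered aromatic ring attached through its 2-position, compound 2 and compound 4, cannot be read, since both stand at the same limit: the limit of > 20000 nM in this assay, at which 3 of the 4 values shown sit.

The compounds shown leave open whether any group at this carbon, such as an amine, a carboxylic acid or a longer chain, would give a clear number on the shared core. They also leave open how thiophen-3-yl would read there.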